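A few compounds are considered here, and "the series" means these few. Any claim that something is new, unique, unknown or untested is made for them only; others in the source may bear on it.

For the measured compounds named here, compound 2 `Oc1ccccc1/C=N/c1nnc(SCc2nnc(-c3ccccc3Br)o2)s1` has the lower of the two numbers so far in a functional assay on SMMC-7721 cells (Homo sapiens) for inhibition, read by CCK-8 assay (a lower number here means a stronger inhibitor, a higher number a weaker inhibitor), giving 6780 nM, while compound 1 `Oc1ccccc1/C=N/c1nnc(SCc2nnc(-c3ccccc3)o2)s1` gives 7100 nM; the two sit within the scatter of each other. Compound 3 `Cc1cccc(-c2nnc(CSc3nnc(/N=C/c4ccccc4O)s3)o2)c1` differs from compound 2 by 3-methylphenyl in place of 2-bromophenyl on an aromatic carbon. Going by the values given here, the only step that bears on this position, a 1.0-fold lower number from compound 1 to compound 2 (0.02 log units; within the scatter), was within the scatter, so a change at this place has not moved the number so far. Compound 3 is therefore expected to give 7000 nM, in a range of 3000 nM to 16000 nM, with an expected step of a 1.0-fold higher number from compound 2 to compound 3 (0.01 log units; within the scatter).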

Compound 3, half-maximal inhibitory concentration: 4550 nM
Compound 3: middle estimate off by 1.5-fold (0.19 log units), on the high side; the range from low to high includes it.
By their numbers in this assay, from the lowest: compounds 3, 2 and 1 (each within the scatter of the next).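

In this assay the exchange of 2-bromophenyl for 3-methylphenyl gives a 1.5-fold lower number from compound 2 to compound 3 (0.17 log units; within the scatter) and methyl in place of hydrogen gives a 1.6-fold lower number from compound 1 to compound 3 (0.19 log units; within the scatter) as the second step at this place. Both steps lie within the scatter, so a methyl on the ring, like the bromo before it, does not separate these compounds. Nothing available explains where these numbers fall.
On these data alone, whether an amine or a carboxylic acid on this ring would carry the number beyond the scatter remains open. So does whether any change at this place matters at all.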